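This account rests on a few compounds, and the source may have more. Where it says the series, first, only, none or still open, it means among the compounds named here.

The measured compounds, with their solubility numbers in phosphate buffer:

compound 1 `COc1ncnc2c1ncn2[C@@H]1O[C@H](COC(=O)C(C)C)[C@@H](OC(=O)C(C)C)[C@@H]1OC(=O)C(C)C` gives 141000 nM
compound 2 `COc1ncnc2c1ncn2[C@@H]1O[C@H](CO)[C@@H](OC(=O)C(C)C)[C@@H]1OC(=O)C(C)C` gives 3300000 nM
compound 3 `COc1ncnc2c1ncn2[C@@H]1O[C@H](COC(C)=O)[C@@H](O)[C@@H]1OC(C)=O` gives 7100000 nM

In a physicochemical assay for solubility, in phosphate buffer (a higher number here means a more soluble compound, a lower number a less soluble compound), compound 1 stands lowest of the three. Compound 2 lies a good way above it, with a 23-fold higher number from compound 1 to compound 2 (1.37 log units; beyond the scatter), and compound 3 lies further still; compound 3 differs from compound 1 in more than one place, so its value only shows where it sits.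

Compound 4 `COc1ncnc2c1ncn2[C@@H]1O[C@H](COC(=O)C(C)C)[C@@H](OC(=O)C(C)C)[C@@H]1O` is the next compound to consider. It differs from compound 1 in one place: hydrogen in place of isopropylcarbonyl on an oxygen on a saturated carbon. Among the compounds with values here, this is the same kind of change as the one from compound 1 to compound 2, made on a different oxygen of the shared core. Within the data shown here, that measured step, a 23-fold higher number from compound 1 to compound 2 (1.37 log units; beyond the scatter), is large and beyond the scatter, and it is the only step here that bears directly on the change. A rise of a similar order is therefore expected in this assay for compound 4, though the different oxygen leaves some room for a smaller or larger move, so the expected step is a 14-fold higher number from compound 1 to compound 4 (1.15 log units; beyond the scatter).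

For compound 4 the estimate in this assay is 2000000 nM, with an expected range from 600000 nM to 6000000 nM.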

Compound 4, solubility: 428000 nM
Estimate against measurement, compound 4: 4.7-fold (0.67 log units) above; measured number below the stated range.
By their numbers in this assay, from the lowest: compound 1; then compound 4; then compound 2; then compound 3.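

At this oxygen, swapping isopropylcarbonyl for hydrogen also raises the number in this assay, with a 3.0-fold higher number from compound 1 to compound 4 (0.48 log units; beyond the scatter) as the step, so the direction seen earlier holds on a second oxygen of the shared core. The size does not carry over: the same swap on the other oxygen gave a 23-fold higher number from compound 1 to compound 2 (1.37 log units; beyond the scatter) as its step, a large move against a modest one here, so this change cannot be read as one fixed gain wherever an isopropylcarbonyl leaves. No measurement at hand explains why the two oxygens differ in this way.

The compounds shown leave open what the same swap does on the third oxygen carrying an isopropylcarbonyl, and whether removing two of these groups from compound 1 would add up to the two single steps or come to something else. They also leave open how this hydroxy oxygen would respond to groups other than hydrogen and isopropylcarbonyl, such as a longer acyl chain or an ester carrying an amine, since only these two end points of the change can be compared here.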